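This account rests on a few compounds, and the source may have more. Where it says the series, first, only, none or still open, it means among the compounds named here.

Of the compounds shown here, two sharing one core have been tested in an assay on isolated protein for displacement of a labelled ligand from Glucagon receptor (Homo sapiens); on this read-out higher numbers stand for weaker inhibition and lower numbers for stronger inhibition. Compound 1 `CCCC(Oc1cnn(-c2cccc(C)c2)c1)c1ccc(C(=O)NCCC(=O)O)cc1` gives 1110 nM in this assay. Compound 2 `CCCC(Oc1cnn(-c2ccc(OC)cc2)c1)c1ccc(C(=O)NCCC(=O)O)cc1` carries a 4-methoxyphenyl in place of the 3-methylphenyl on an aromatic nitrogen, and in this assay compound 2 gives 1980 nM. Among the measured compounds shown here, the only step measured so far is a 1.8-fold higher number from compound 1 to compound 2 (0.25 log units; within the scatter), so compound 2 stands at the larger of the two numbers, yet the gap is within the scatter and the two cannot be told apart. Compound 3 `CCCC(Oc1cnn(-c2ccccc2C)c1)c1ccc(C(=O)NCCC(=O)O)cc1` is the next point: 2-methylphenyl in place of 4-methoxyphenyl on an aromatic nitrogen. For the measured compounds named here, no measured compound carries a 2-methylphenyl, and the one known step was small, so the expectation for a 1.5-fold lower number from compound 2 to compound 3 (0.18 log units; within the scatter) is a step no larger than the scatter, if anything toward a lower number. Compound 3 is therefore estimated to give about 1300 nM in this assay, within a range from 500 nM to 3500 nM.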

Compound 3, inhibition constant: 14700 nM
For compound 3 the middle estimate is 11-fold (1.05 log units) below the measured one; the measured number lies above the stated range.
By their numbers in this assay, from the lowest: compounds 1 and 2 (each within the scatter of the next); then compound 3.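

In this assay, 2-methylphenyl in place of 3-methylphenyl gives a 13-fold higher number from compound 1 to compound 3 (1.12 log units; beyond the scatter), so the place of the methyl on this phenyl ring matters even though the group stays a methylphenyl. The replacement of 4-methoxyphenyl by 2-methylphenyl gives a 7.4-fold higher number from compound 2 to compound 3 (0.87 log units; beyond the scatter), which shows that this position on the aromatic nitrogen does not accept every substituted phenyl equally, although compounds 1 and 2 could not be told apart. Nothing available explains why the 2-methylphenyl compound stands apart.

The compounds shown leave open whether this weaker binding goes with the 2-methylphenyl alone or would also appear with a 2-methoxyphenyl or a 2-chlorophenyl. They also leave open how an unsubstituted phenyl would compare with all three groups.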